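Aryl variation at the amide-bearing carbon: compound 4

The compounds below may be only part of what the source reports. "The series", "measured", "known", "first", "only" and "open" are said of these compounds alone.

Measured in an assay on isolated protein for inhibition of RAC-alpha serine/threonine-protein kinase (Homo sapiens); a lower number here means a stronger inhibitor, a higher number a weaker inhibitor:
compound 1 `O=C(NC(c1ccc2ccccc2c1)C1CCNCC1)c1ccc2cnccc2c1` gives 400 nM
compound 2 `O=C(NC(c1nccs1)C1CCNCC1)c1ccc2cnccc2c1` gives 1570 nM
compound 3 `O=C(NC(c1ccc(F)c(F)c1)C1CCNCC1)c1ccc2cnccc2c1` gives 2680 nM

Compound 3 sits at the weak end of these three: the step of a 6.7-fold higher number from compound 1 to compound 3 (0.83 log units; beyond the scatter) is beyond the scatter, whereas a 1.7-fold higher number from compound 2 to compound 3 (0.23 log units; within the scatter) is within it, so compound 2 and compound 3 cannot be separated. Compound 4 `N#Cc1cc(C(NC(=O)c2ccc3cnccc3c2)C2CCNCC2)ccc1Cl` carries 4-chloro-3-cyanophenyl in place of 3,4-difluorophenyl on a saturated chain carbon bound to an amide-type nitrogen and a saturated ring carbon. Among the compounds with values here, no measured step exchanges one substituted phenyl for another. The relevant comparisons are a 6.7-fold higher number from compound 1 to compound 3 (0.83 log units; beyond the scatter), a move away from the two-ring group, and a 1.7-fold higher number from compound 2 to compound 3 (0.23 log units; within the scatter), a swap of one single aromatic ring for another that stayed within scatter. A swap of one six-membered ring for another is therefore expected to change little in this assay. The expected step is a 1.3-fold lower number from compound 3 to compound 4 (0.13 log units; within the scatter). Compound 4 is estimated at 2000 nM, range 700 nM to 6000 nM.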

Compound 4, half-maximal inhibitory concentration: 80 nM
Compound 4: middle estimate off by 25-fold (1.40 log units), on the high side; measured number outside the range, below it.
By their numbers in this assay, from the lowest: compound 4; then compound 1; then compounds 2 and 3 (each within the scatter of the next).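

In this assay this position proves far more responsive to single-ring changes than compound 2 and compound 3 suggested, with a 34-fold lower number from compound 3 to compound 4 (1.53 log units; beyond the scatter) and a 20-fold lower number from compound 2 to compound 4 (1.29 log units; beyond the scatter) both large. The two-ring group is also not needed for the lowest number in the set, given a 5.0-fold lower number from compound 1 to compound 4 (0.70 log units; beyond the scatter) for 4-chloro-3-cyanophenyl in place of naphthalen-2-yl. Nothing available here accounts for this gain.

From the compounds shown here alone, the nitrile and the chlorine occur only together, so their separate contributions remain open. Also open, going by these compounds, is how an amine or a carboxylic acid on this phenyl ring would read in this assay.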